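Replacing the dichlorophenyl group on the oxadiazoline ring

A few compounds are considered here, and "the series" means these few. Any claim that something is new, unique, unknown or untested is made for them only; others in the source may bear on it.

Compounds measured so far:
compound 1 `COc1ccc(/C=N/NC(=O)c2cc(OC)c(OC)c(OC)c2)c(OC)c1` gives 22.2%
compound 2 `COc1cc(C2=NN(C(C)=O)C(c3c(Cl)cccc3Cl)O2)cc(OC)c1OC` gives -2.2%
compound 3 `COc1cc(C(=O)N/N=C/c2c(Cl)cccc2Cl)cc(OC)c1OC` gives 52.1%

In a functional assay on PC-3 cells (Homo sapiens) for antiproliferative activity, read by MTT assay, tested at 5 uM (on this read-out higher numbers stand for a stronger effect at the one concentration tested and lower numbers for a weaker effect), compound 2 shows the lowest number of the three compounds. Its nearest neighbour is compound 1, whose value is higher by a margin beyond the scatter, and compound 3 lies further above it still. No pair among these three differs in a single place, so no measured step can be drawn from them.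

Compound 4 `COc1cc(C2=NN(C(C)=O)C(c3ccc(Cl)c([N+](=O)[O-])c3)O2)cc(OC)c1OC` has not yet been measured. It differs from compound 2 in one place: 4-chloro-3-nitrophenyl in place of 2,6-dichlorophenyl on a saturated ring carbon The five-membered ring carrying the acetyl group and the trimethoxyphenyl group is kept unchanged in compound 4.

Among the compounds with values here, with no measured step of this kind at hand, only a cautious expectation can be given. The step from compound 2 to compound 4 is expected to be small and upward, a number 12.2 percentage points higher from compound 2 to compound 4 (beyond the scatter), possibly not beyond the scatter. On that basis compound 4 is estimated to give 10% in this assay, within a range from -10% to 35%.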

Compound 4, a percentage reported as inhibition, at one concentration (the size of the read-out at that concentration, not a potency): 61.4%
Estimate against measurement, compound 4: 51.4 percentage points below; measured number outside the range, above it.
By their numbers in this assay, from the lowest: compound 2; then compound 1; then compounds 3 and 4 (each within the scatter of the next).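

In this assay, within the data shown here, the group on the saturated ring carbon proves decisive for this series: with the acetyl group and the trimethoxyphenyl group unchanged, 4-chloro-3-nitrophenyl in place of 2,6-dichlorophenyl gives a large rise, a number 63.6 percentage points higher from compound 2 to compound 4 (beyond the scatter), the first step that can be read here. The five-membered ring bearing the acetyl group is therefore not tied to a number near zero, as compound 2 alone might have suggested, since compound 4 carries that same ring. No measurement at hand gives a reason for the rise.

The compounds shown leave open whether the nitro group, the chlorine or the two together carry this rise, as a phenyl ring bearing only one of them is not among them. They also leave open whether an amine or a carboxylic acid in place of the nitro group would keep the effect.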